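The compounds below may be only part of what the source reports. "The series", "measured", "known", "first", "only" and "open" are said of these compounds alone.

In an assay on cells for inhibition of HSP60/HSP10 (Homo sapiens), with a stated time of 60 min (on this read-out lower numbers stand for stronger inhibition and higher numbers for weaker inhibition), compound 1 `O=S(=O)(Nc1ccc(-c2nc3ccccc3o2)cc1)c1ccccc1F` gives only a limit, > 100000 nM. In this assay compound 2 `COc1ccccc1S(=O)(=O)Nc1ccc(-c2nc3ccccc3o2)cc1` likewise gives only a limit, > 100000 nM. Among the compounds with values here, the single measured step, a step that the two limits leave unreadable from compound 1 to compound 2, therefore has no readable size, since both values sit at the limit of > 100000 nM in this assay, at which 2 of the 2 values shown sit. Compound 3 `O=S(=O)(Nc1ccc(-c2nc3ccccc3o2)cc1)c1ccccc1C(F)(F)F` differs from compound 2 by trifluoromethyl in place of methoxy on an aromatic carbon. Within the data shown here, no measured step covers this change, and the one step at hand gives no size, so in this assay no direction beyond the scatter can be expected. Compound 3 is estimated at 150000 nM, expected between 20000 nM and 1000000 nM, most likely again reported only as a limit. The expected step is a step that the limit leaves unreadable from compound 2 to compound 3.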

Compound 3, half-maximal inhibitory concentration: 74000 nM
For compound 3 the middle estimate is 2.0-fold (0.31 log units) above the measured one; the measured number falls inside the stated range.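

In this assay trifluoromethyl, on an aromatic carbon ortho to a large group, gives compound 3 a readable number, while fluoro in compound 1 and methoxy in compound 2 give only a limit: the limit of > 100000 nM in this assay, at which 2 of the 3 values shown sit. The change appears as an at least 1.3-fold lower number from compound 2 to compound 3 (0.13 log units; that floor lies within the scatter) and as an at least 1.3-fold lower number from compound 1 to compound 3 (0.13 log units; that floor lies within the scatter). From the compounds shown here alone, both are only floors within the scatter, so the true size of these steps stays unknown, and the step between the two limits cannot be read.

Going by these compounds, whether an amine, a nitrile or a carboxylic acid at this position would lower the number further stays open. So does whether trifluoromethyl would give a readable number elsewhere on this ring.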